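Shortening the ester chain: from compound 1 to compound 3

The compounds below may be only part of what the source reports. "The series", "measured", "known", "first", "only" and "open" are said of these compounds alone.

Measured so far:
- compound 1, `CC(C)CC(=O)Oc1ccc2oc(/C=C/[S+](C)[O-])cc(=O)c2c1`: 6100 nM
- compound 2, `COc1cccc2c(=O)cc(/C=C/[S+](C)[O-])oc12`: 9000 nM

In a functional assay on DLD-1 cells (Homo sapiens) for cytotoxicity, with a stated time of 48 h (on this read-out lower numbers stand for stronger inhibition and higher numbers for weaker inhibition), compound 1 gives the lower of the two numbers, yet compound 2 stands close enough that the gap lies within the usual scatter of repeated runs, so the two cannot be ordered against each other. Both carry the shared core with the vinyl sulfoxide side chain; they differ in the substituent on the fused ring, and no single-step comparison between them is available.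

Compound 3, `CCC(=O)Oc1ccc2oc(/C=C/[S+](C)[O-])cc(=O)c2c1`, has not yet been measured in this assay. Relative to compound 1 the change is methyl in place of isopropyl on a saturated chain carbon bound to a carbonyl carbon. The ester itself stays in place; only the saturated chain attached to the carbonyl carbon shrinks, from isobutyl to ethyl.

Nothing measured here tells how this series responds to shortening the ester chain. With the rest of compound 1 unchanged, the expected step is small, with no clear direction and most likely none beyond the scatter, which for a 1.1-fold higher number from compound 1 to compound 3 (0.06 log units; within the scatter) means roughly a flat outcome. Compound 3 is therefore expected near 7000 nM, within 2500 nM to 20000 nM.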

Compound 3, half-maximal inhibitory concentration: 9000 nM
For compound 3 the middle estimate is 1.3-fold (0.11 log units) below the measured one; the measured number falls inside the stated range.
By their numbers in this assay, from the lowest: compounds 1, 2 and 3 (each within the scatter of the next).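

Within this assay, cutting the ester chain from isobutyl to ethyl gives a 1.5-fold higher number from compound 1 to compound 3 (0.17 log units; within the scatter), the first single-place comparison in this series. Methyl in place of isopropyl on a saturated chain carbon bound to a carbonyl carbon therefore leaves no readable step, so the chain can go from 3 heavy atoms to 1 at this carbon without the number leaving the scatter. No accompanying measurement bears on why the step comes out this way.

Still open, as far as these compounds go, is whether this flat reading holds only for small saturated chains, or whether a longer chain such as octanoyl, a phenyl ring or a terminal amine or carboxylic acid on the same carbon would give a step beyond the scatter. From the compounds shown here alone, it is equally open whether the ester oxygen matters at all, since an amide linkage or a free hydroxyl in place of the propanoyloxy group would test the link itself rather than the chain that hangs from it.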